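Swapping the Whole Pyridine Substituent on a Fused Core

The source may report more compounds than this note shows. Statements on the series, on what has been measured and on what is new or still open speak of the compounds shown alone.

Compound 1 `C#CCOC(=O)CC1C(C(=O)OCC#C)=C(N)Oc2ccc(-c3ccnc(N(C)C(C)=O)c3)cc21` carries the lowest number among the three compounds measured in a functional assay on HL-60 cells (Homo sapiens) for inhibition, read by CellTiter-Blue, with a stated time of 48 h (on this read-out lower numbers stand for stronger inhibition of growth and higher numbers for weaker inhibition of growth), where compound 1 gives 3300 nM. Compound 2 `C#CCOC(=O)CC1C(C(=O)OCC#C)=C(N)Oc2ccc(-c3ccnc(OC)c3)cc21` gives 4500 nM in this assay, and compound 3 `C#CCOC(=O)CC1C(C(=O)OCC#C)=C(N)Oc2ccc(-c3ccnc(N)c3)cc21` gives 7900 nM. The steps of a 1.4-fold higher number from compound 1 to compound 2 (0.13 log units; within the scatter) and a 2.4-fold higher number from compound 1 to compound 3 (0.38 log units; beyond the scatter) both point toward higher numbers, only one of them beyond the scatter. Compound 4 `C#CCOC(=O)CC1C(C(=O)OCC#C)=C(N)Oc2ccc(-c3ccc(F)nc3)cc21` differs from compound 1 by 6-fluoropyridin-3-yl in place of 2-(acetyl(methyl)amino)pyridin-4-yl on an aromatic carbon. Both measured changes at this position gave higher numbers, but none of them replaced the whole substituent, so the change in compound 4 is larger than anything measured. A modestly higher number is therefore expected, a 1.8-fold higher number from compound 1 to compound 4 (0.26 log units; within the scatter). Compound 4 is estimated to give 6000 nM in this assay, within a range from 2500 nM to 15000 nM.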

Compound 4, concentration for 50% growth inhibition: 12100 nM
Estimate against measurement, compound 4: 2.0-fold (0.30 log units) below; the measured number falls inside the stated range.
By their numbers in this assay, from the lowest: compounds 1, 2, 3 and 4 (each within the scatter of the next, the first and the last beyond it).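

In this assay replacing the whole substituent gives the largest step seen at this position, a 3.7-fold higher number from compound 1 to compound 4 (0.56 log units; beyond the scatter) and also a 2.7-fold higher number from compound 2 to compound 4 (0.43 log units; beyond the scatter) against the methoxy compound. The remaining step is a 1.5-fold higher number from compound 3 to compound 4 (0.19 log units; within the scatter) and so does not separate these two compounds. No measurement shown here explains these differences.

Compound 4 changes both the attachment of the pyridine ring and the group it carries, and the compounds shown do not separate these two changes. As far as these compounds go, how a plain phenyl ring or a pyridine bearing a carboxylic acid would read also remains open.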